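Replacing Chloro with Fluoro on the Aryl Ring

The compounds below may be only part of what the source reports. "The series", "measured", "known", "first", "only" and "open" are said of these compounds alone.

Measured in a functional assay (aorta) for inhibition, with Rattus norvegicus as the target; on this read-out higher numbers stand for weaker inhibition and lower numbers for stronger inhibition:
- Compound 1 `Cc1nsc(-c2ccc(N3CCN(c4cccc(Cl)c4)CC3)nn2)n1`: 0.6 nM
- Compound 2 `Cc1nsc(-c2nccc(N3CCN(c4cccc(C(F)(F)F)c4)CC3)n2)n1`: > 100 nM
- Compound 3 `Cc1nsc(-c2ccnc(N3CCN(c4cccc(C(F)(F)F)c4)CC3)n2)n1`: > 100 nM

Among the measured compounds shown here, compound 1 gives 0.6 nM, the only exact number of the three. Compound 2 gives > 100 nM, which is a limit of the assay and not a number. Compound 3 gives > 100 nM, again a limit and not a number.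

The next compound to be measured is compound 4 `Cc1nsc(-c2ccc(N3CCN(c4cccc(F)c4)CC3)nn2)n1`. It keeps the core of compound 1 but has fluoro in place of chloro on an aromatic carbon, turning 3-chlorophenyl into 3-fluorophenyl (fluoro in place of chloro on an aromatic carbon). For the measured compounds named here, no measured pair differs in one place only, so the data offer no direct guide to this change. In this assay, a small move towards a higher number is expected, starting from compound 1 at 0.6 nM, and it may not exceed the scatter. The expected size of the change is a 2.5-fold higher number from compound 1 to compound 4 (0.40 log units; beyond the scatter). Compound 4 is estimated at 1.5 nM, with an expected range of 0.3 nM to 10 nM.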

Compound 4, half-maximal inhibitory concentration: 6 nM
Estimate against measurement, compound 4: 4.0-fold (0.60 log units) below; the measured number falls inside the stated range.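

Fluoro in place of chloro on an aromatic carbon gives the first reading of a single change in this assay, and it is a 10-fold higher number from compound 1 to compound 4 (1.00 log units; beyond the scatter). The position, on an aromatic carbon meta to a large group, thus responds to which halogen it carries, even though one heavy atom replaces one heavy atom and the counts of donors and acceptors stay the same. Compound 4 still gives an exact number and not a limit, so the full size of this step can be read: the limit of > 100 nM in this assay, at which 2 of the 4 values shown sit.

The compounds shown leave open how a methyl, a methoxy or a nitrile at this position would compare with chloro and fluoro on the same core. Trifluoromethyl appears only in compound 2 and compound 3, whose cores differ from that of compound 1, so no step to it can be read.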